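A few compounds are considered here, and "the series" means these few. Any claim that something is new, unique, unknown or untested is made for them only; others in the source may bear on it.

Measured compounds:
- compound 1, `O=C1/C(=C/c2ccccc2Br)CCc2ccccc21`, 25400 nM
- compound 2, `O=C(/C=C/c1cccc([N+](=O)[O-])c1)c1ccccc1`, 8900 nM

In a functional assay on CCRF-CEM cells (Homo sapiens) for inhibition (a lower number here means a stronger inhibitor, a higher number a weaker inhibitor), compound 1 gives 25400 nM, the highest of the two numbers recorded. Its nearest neighbour is compound 2, which in this assay gives 8900 nM, a lower number, and the gap between the two lies beyond the usual scatter. The two compounds share no single-point relationship, since their cores differ as well as their substituents, so the pair says only that much.

Compound 3, `O=C1/C(=C/c2ccccc2[N+](=O)[O-])CCc2ccccc21`, has not yet been measured in this assay. It is built on the core of compound 1, and the change is nitro in place of bromo on an aromatic carbon. Going by the values given here, no measured pair isolates this exchange, so there is no precedent within the set for its size or direction. Among the compounds with values here, the only other nitro-bearing compound, compound 2, gives 8900 nM, but on a different core, so it offers no more than a loose hint.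

The step is therefore expected to be a 1.7-fold lower number from compound 1 to compound 3 (0.23 log units; within the scatter), a modest move toward a lower number that may well fall within the scatter. Compound 3 is expected to give 15000 nM in this assay, within a range from 5000 nM to 50000 nM.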

Compound 3, half-maximal inhibitory concentration: 7220 nM
Estimate against measurement, compound 3: 2.1-fold (0.32 log units) above, within the range that was stated.
By their numbers in this assay, from the lowest: compounds 3 and 2 (each within the scatter of the next); then compound 1.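

In this assay, going by these compounds alone, placing nitro in place of bromo on this aromatic carbon, ortho to a large group, gives a 3.5-fold lower number from compound 1 to compound 3 (0.55 log units; beyond the scatter) and supplies the first single-point step in the set. This shows that, on the core of compound 1, the group at this carbon matters to the read-out, and the step runs toward a stronger inhibitor by a margin beyond the scatter. That conclusion rests on this one pair alone, and no measurement at hand offers an explanation for the step.

From the compounds shown here alone, it remains open whether this result is particular to nitro or would also be seen with another group on the same carbon, such as an amine, a methoxy group, a nitrile or chlorine. It is equally open whether the exchange would carry over to the core of compound 2, for which the compounds shown include no bromo partner, and whether nitro would give a similar number on another carbon of the same aromatic ring.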